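Chain Extension Repeated on a Second Linker Core

The source may hold more compounds than are shown below. What is called first, only, known or untested is meant among the compounds shown, and "the series" means these compounds.

Compound 1 `CCCc1c(OCCCCCOc2c(C(C)=O)ccc(OCC(=O)O)c2CCC)ccc(C(C)=O)c1O` carries two linked aromatic parts, each bearing an acetyl group, with a carboxymethoxy arm on one side. In a functional assay on ileum (Cavia porcellus) for inhibition of cysteinyl leukotriene receptor (Homo sapiens) (a higher number here means a weaker inhibitor, a lower number a stronger inhibitor), compound 1 gives 100 nM. Compound 2 `CCCc1c(OCCCCCOc2c(C(C)=O)ccc(OCCCC(=O)O)c2CCC)ccc(C(C)=O)c1O` differs in one place, (2-carboxyethyl in place of carboxy on a saturated chain carbon bound to an oxygen on an aromatic ring), and in this assay compound 2 gives 1000 nM. That change gave a 10-fold higher number from compound 1 to compound 2 (1.00 log units; beyond the scatter). Compound 3 `CCCc1c(OCCCOCCCOc2c(C(C)=O)ccc(OCC(=O)O)c2CCC)ccc(C(C)=O)c1O` has a different linker between the two aromatic parts, and its difference from compound 1 is not broken down here. In this assay compound 3 gives 400 nM. Compound 4 `CCCc1c(OCCCOCCCOc2c(C(C)=O)ccc(OCCCC(=O)O)c2CCC)ccc(C(C)=O)c1O` is not yet measured; it differs from compound 3 by 2-carboxyethyl in place of carboxy on a saturated chain carbon bound to an oxygen on an aromatic ring, the same change as from compound 1 to compound 2, at the same kind of place. Because the earlier step was a 10-fold higher number from compound 1 to compound 2 (1.00 log units; beyond the scatter), a step of similar size is expected here, namely a 10-fold higher number from compound 3 to compound 4 (1.00 log units; beyond the scatter). This rests on a single earlier instance, so the expected range is kept wide. Compound 4 is thus estimated at 4000 nM, expected to fall between 1500 nM and 10000 nM.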

Compound 4, half-maximal inhibitory concentration: 200 nM
Estimate against measurement, compound 4: 20-fold (1.30 log units) above, and the stated range ends above it.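

On the core of compound 3, going from the carboxymethoxy arm to the 3-carboxypropoxy arm gave a 2.0-fold lower number from compound 3 to compound 4 (0.30 log units; within the scatter) in this assay, so this pair cannot be told apart in this test. The change therefore did not carry over from one core to the other, and the two steps differ by more than repeat measurements would explain: the same change on two cores in this assay, a 10-fold higher number (1.00 log units; beyond the scatter) from compound 1 to compound 2 and a 2.0-fold lower number (0.30 log units; within the scatter) from compound 3 to compound 4, 20-fold (1.30 log units) apart, beyond the scatter of two such steps. This shows that the result of the change depended on the core in these two pairs, but two cores give no rule for a third and do not show why the steps differ.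

Still open, as far as these compounds go, is whether a longer all-carbon linker would behave like the linker of compound 1 or like that of compound 3, which would help separate linker length from the oxygen within it. From the compounds shown here alone, it is also open how a tetrazole in place of the carboxylic acid, or a still longer acid chain, would fare on each core.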